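The source may report more compounds than this note shows. Statements on the series, on what has been measured and on what is new or still open speak of the compounds shown alone.

In a functional assay on BXPC-3 cells (Homo sapiens) for antiproliferative activity, read by sulforhodamine B assay, with a stated time of 72 h (a lower number here means a stronger inhibitor, a higher number a weaker inhibitor), compound 1 `CC(C)(C)c1[nH]cnc1/C=c1\[nH]c(=O)/c(=C/c2cccc(C(=O)N3CCC3)c2)[nH]c1=O` reads > 500 nM as a limit of the assay and not a number. Within the data shown here, compound 2 `CC(C)(C)c1[nH]cnc1/C=c1\[nH]c(=O)/c(=C/c2cccc(C(=O)N3CCCCC3)c2)[nH]c1=O` gives 100 nM and is the only compound so far with a true number. Compound 3 `CC(C)(C)c1[nH]cnc1/C=c1\[nH]c(=O)/c(=C/c2cccc(C(=O)c3ccncc3)c2)[nH]c1=O` differs from compound 2 by the change pyridin-4-yl in place of piperidin-1-yl on a carbonyl carbon in which pyridin-4-yl takes the place of piperidin-1-yl on a carbonyl carbon. Among the measured compounds shown here, one measured step bears on this place: putting piperidin-1-yl in place of azetidin-1-yl gave an at least 5.0-fold lower number from compound 1 to compound 2 (0.69 log units; beyond the scatter) and so the ring held here can shift the number beyond the scatter. A similarly modest step toward a lower number is expected, though the direction is uncertain, and the estimate is a 2.0-fold lower number from compound 2 to compound 3 (0.30 log units; within the scatter) in this assay for this change. Compound 3 is expected at 50 nM with an estimated range from 8 nM to 300 nM.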

Compound 3, half-maximal inhibitory concentration: 23.8 nM
The estimate for compound 3 lay 2.1-fold (0.32 log units) above the measured number; measured number inside the range.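

Swapping piperidin-1-yl for pyridin-4-yl on the carbonyl carbon keeps the heavy-atom count but gives a 4.2-fold lower number from compound 2 to compound 3 (0.62 log units; beyond the scatter) in this assay, so ring size alone does not set the number here. Against azetidin-1-yl, the same ring gives an at least 21-fold lower number from compound 1 to compound 3 (1.32 log units; beyond the scatter). That step is open-ended, since compound 1 carries a limit and not a number: the limit of > 500 nM in this assay, at which 1 of the 3 values shown sits.

Aromatic character and the way the ring is joined to the carbonyl change together, so their separate contributions remain open. A phenyl ring on the carbonyl carbon would help to tell them apart.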